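This account rests on a few compounds, and the source may have more. Where it says the series, first, only, none or still open, it means among the compounds named here.

Compound 2 `COc1cc(-c2cc(/C=C/C(=O)c3ccc(N)cc3)[nH]n2)cc(OC)c1OC` and compound 1 `COc1ccc(-c2cc(/C=C/C(=O)c3ccc(N)cc3)[nH]n2)cc1` share one core and differ only in the substituents on the outer aromatic ring. In a functional assay on RXF 393 cells (Homo sapiens) for cytotoxicity, read by sulforhodamine B assay, with a stated time of 48 h, tested at 0.01 uM (a higher number here means a weaker effect of the compound at the concentration tested, a lower number a stronger effect), compound 2 gives 91%, and compound 1 gives 95% in this assay; the two numbers lie within the scatter of each other, so neither stands apart. Compound 3 `COc1ccc(-c2cc(/C=C/C(=O)c3ccc(N)cc3)[nH]n2)cc1OC` follows from compound 2 by the change (hydrogen in place of methoxy on an aromatic carbon). Since removing two methoxy groups left the number unchanged beyond the scatter, the expected step of a number 2 percentage points higher from compound 2 to compound 3 (within the scatter) in this assay is none beyond the scatter. Compound 3 is therefore expected to give about 93%, between 80% and 105%, in this assay.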

Compound 3, a percentage reported as activity, at one concentration (the size of the read-out at that concentration, not a potency): 99%
Compound 3: the middle estimate sits 6 percentage points below what was measured; measured number inside the range.
By their numbers in this assay, from the lowest: compounds 2, 1 and 3 (each within the scatter of the next).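

In this assay, hydrogen in place of methoxy, ortho to a methoxy group, gives a number 8 percentage points higher from compound 2 to compound 3 (within the scatter), and methoxy in place of hydrogen gives a number 4 percentage points higher from compound 1 to compound 3 (within the scatter). With each methoxy change now read singly, neither step separates the compounds at this concentration, so this position shows no effect of the change here. Nothing available explains this result. On these data alone, whether a hydroxyl, an amine or a longer alkoxy chain at this position would move the number beyond the scatter remains open. So does how these compounds compare at other concentrations.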